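This account rests on a few compounds, and the source may have more. Where it says the series, first, only, none or still open, it means among the compounds named here.

Compound 1 `COc1cc2c(Oc3ccc(NC(=O)c4nnn(-c5ccc(F)cc5)c4C(F)(F)F)cc3F)ccnc2cc1OCCCN1CCCCC1`: in a functional assay on U-87MG ATCC cells (Homo sapiens) for cytotoxicity, read by MTT assay, with a stated time of 72 h (on this read-out higher numbers stand for weaker inhibition and lower numbers for stronger inhibition), compound 1 gives 1100 nM.
Compound 2 `COc1cc2c(Oc3ccc(NC(=O)c4nnn(-c5ccc(F)cc5)c4C(F)(F)F)cc3F)ccnc2cc1OCCCN1CCC(C)CC1`: in this assay compound 2 gives 800 nM.

Of these two numbers, compound 2 carries the lower one, but the step of a 1.4-fold lower number from compound 1 to compound 2 (0.14 log units; within the scatter) lies within the scatter of repeated measurements, so the two compounds cannot be told apart on this read-out.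

Compound 3 `COc1cc2c(Oc3ccc(NC(=O)c4nnn(-c5ccccc5C(F)(F)F)c4C(F)(F)F)cc3F)ccnc2cc1OCCCN1CCC(C)CC1` differs from compound 2 in a single place: 2-(trifluoromethyl)phenyl in place of 4-fluorophenyl on an aromatic nitrogen. Within the data shown here, no measured step bears on this part of the molecule. Among the measured compounds shown here, the only step available, a 1.4-fold lower number from compound 1 to compound 2 (0.14 log units; within the scatter), concerns a methyl on the saturated ring at the opposite end of the shared core and was within the scatter, so it gives no guide to a change on the aromatic nitrogen. With nothing to point either way, compound 3 is expected to land near compound 2, at about 900 nM, with a range from 300 nM to 2700 nM, which amounts to an expected step of a 1.1-fold higher number from compound 2 to compound 3 (0.05 log units; within the scatter).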

Compound 3, half-maximal inhibitory concentration: 1240 nM
The estimate for compound 3 lay 1.4-fold (0.14 log units) below the measured number; low and high end bracket the measured number.
By their numbers in this assay, from the lowest: compounds 2, 1 and 3 (each within the scatter of the next).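

Among these compounds, the step at this position gives the first reading on the aromatic nitrogen of the five-membered ring, the end of the molecule far from the methyl of the earlier step. Replacing 4-fluorophenyl with 2-(trifluoromethyl)phenyl gives a 1.6-fold higher number from compound 2 to compound 3 (0.19 log units; within the scatter) in this assay, so compound 2 and compound 3 cannot be told apart on this read-out. No measurement shown here offers an explanation for this result.

With only these two groups at the position, the separate parts played by the fluorine and the trifluoromethyl stay unresolved. From the compounds shown here alone, it also remains open whether a phenyl ring bearing an amine or a carboxylic acid, or a plain alkyl chain on that nitrogen, would move the number beyond the scatter.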